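The source may report more compounds than this note shows. Statements on the series, on what has been measured and on what is new or still open speak of the compounds shown alone.

Values in a functional assay on SNO cells (Homo sapiens) for cytotoxicity, read by XTT assay, with a stated time of 24 h; a lower number here means a stronger inhibitor, a higher number a weaker inhibitor:
- compound 1 `Cc1cc(Cl)c2c(c1O)C(=O)C=CC2=O`: 9400 nM
- compound 2 `CC(=O)Oc1cc(OC(C)=O)c2c(OC(C)=O)c(C)cc(Cl)c2c1OC(C)=O`: 53500 nM
- compound 3 `Cc1cc(O)c2c(c1Cl)C(=O)C=CC2=O`: 17200 nM

Compound 1, at 9400 nM, lies within the scatter of compound 3, so these two cannot be separated on the present numbers. Compound 2 lies beyond the scatter from compound 1, on the higher side.

The next compound to be read is compound 4 `CCOc1c(C)cc(Cl)c2c1C(=O)C=CC2=O`. It keeps the core of compound 1 and replaces the hydroxy with ethoxy, which puts ethyl in place of hydrogen on an oxygen on an aromatic ring.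

Among the measured compounds shown here, no measured pair isolates this change, so the expectation in this assay is a cautious one: a small move towards a higher number, possibly none beyond the scatter. The expected step is a 1.4-fold higher number from compound 1 to compound 4 (0.14 log units; within the scatter). The estimate for compound 4 is 13000 nM, with an expected range of 5000 nM to 35000 nM.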

Compound 4, half-maximal inhibitory concentration: 37300 nM
Compound 4: middle estimate off by 2.9-fold (0.46 log units), on the low side, and the stated range ends below it.
By their numbers in this assay, from the lowest: compounds 1 and 3 (each within the scatter of the next); then compounds 4 and 2 (each within the scatter of the next).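

In this assay, among the compounds shown here, ethyl in place of hydrogen on an oxygen on an aromatic ring gives a 4.0-fold higher number from compound 1 to compound 4 (0.60 log units; beyond the scatter), the first change confined to one place and a step beyond the scatter. This position is therefore not indifferent to the change: on the core of compound 1, the hydroxy goes with the lower number, and the ethoxy of compound 4 brings 37300 nM. Nothing measured here accounts for the step, so its cause stays unassigned.

A single step cannot show whether the number follows the length of the chain or simply the loss of the hydroxy hydrogen, a question that methoxy or butoxy on the same oxygen would address. Also open, on these data alone, is whether ethyl on the hydroxy of compound 3 would bring a similar step.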